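Trifluoromethyl on compound 1: expected step

A few compounds are considered here, and "the series" means these few. Any claim that something is new, unique, unknown or untested is made for them only; others in the source may bear on it.

In a functional assay on HeLa cells (Homo sapiens) for inhibition, read by MTT assay, with a stated time of 72 h (on this read-out lower numbers stand for stronger inhibition and higher numbers for weaker inhibition), compound 1 (`COc1cc(OC)c(OC)cc1/C=C/C(=O)c1ccccc1`) stands only as a limit, > 150000 nM. Compound 2 (`COc1cc(OC)c(OC)cc1/C=C/C(=O)c1ccc(C)cc1`) gives 42200 nM. Compound 3 (`COc1cc(OC)c(OC)cc1/C=C/C(=O)c1ccc(F)cc1`) gives 28600 nM. The nearest measured changes are an at least 3.5-fold lower number from compound 1 to compound 2 (0.55 log units; beyond the scatter) and an at least 5.2-fold lower number from compound 1 to compound 3 (0.71 log units; beyond the scatter). Between the two substituted compounds, the change is a 1.5-fold lower number from compound 2 to compound 3 (0.17 log units; within the scatter). Compound 4 (`COc1cc(OC)c(OC)cc1/C=C/C(=O)c1cccc(C(F)(F)F)c1`) differs from compound 1 as follows: trifluoromethyl in place of hydrogen on an aromatic carbon. Neither measured step places a group at that position, so both serve only as a rough guide. A lower number of similar size is expected, given an at least 5.2-fold lower number from compound 1 to compound 3 (0.71 log units; beyond the scatter). The expected step is an at least 5.0-fold lower number from compound 1 to compound 4 (0.69 log units; beyond the scatter). For compound 4 the estimate is 30000 nM, with an expected range of 10000 nM to 100000 nM.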

Compound 4, half-maximal inhibitory concentration: > 150000 nM
Compound 4: no number, only a limit (the forecaster's own chance of this, stated with the estimate: 15%); middle value at least 5.0-fold (0.69 log units) from the limit.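

Compound 1 and compound 4 both stand only as limits, so no step can be read between them: the limit of > 150000 nM in this assay, at which 2 of the 4 values shown sit. The compounds shown leave open whether trifluoromethyl in place of hydrogen changes the number at all, and in which direction.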